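The source may hold more compounds than are shown below. What is called first, only, known or untested is meant among the compounds shown, and "the series" means these compounds.

In a functional assay on HCT-116 cells (Homo sapiens) for inhibition, read by CCK-8 assay, with a stated time of 48 h (on this read-out higher numbers stand for weaker inhibition and lower numbers for stronger inhibition), three compounds that share one core have been measured. Compound 1 (`COc1ccc(CN(C(=O)CSc2nc3ccccc3o2)c2cc(OC)c(OC)c(OC)c2)cc1`) gives 3280 nM, compound 2 (`COc1ccc(CN(C(=O)CSC(=S)N2CCN(C)CC2)c2cc(OC)c(OC)c(OC)c2)cc1`) gives 2640 nM, and compound 3 (`CCN1CCN(C(=S)SCC(=O)N(Cc2ccc(OC)cc2)c2cc(OC)c(OC)c(OC)c2)CC1`) gives 7700 nM, the highest of the three numbers and so the weakest inhibition.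

Compound 4 (`COc1ccc(CN(C(=O)CSC(=S)N2CCN(C(C)=O)CC2)c2cc(OC)c(OC)c(OC)c2)cc1`) differs from compound 3 by acetyl in place of ethyl on an amine nitrogen in a ring: in words, acetyl in place of ethyl on an amine nitrogen in a ring. The closest evidence is a 2.9-fold higher number from compound 2 to compound 3 (0.46 log units; beyond the scatter), a modest step from methyl in place of hydrogen on the group at that same nitrogen. Larger swaps on the sulfur gave a 1.2-fold lower number from compound 1 to compound 2 (0.09 log units; within the scatter) and a 2.3-fold higher number from compound 1 to compound 3 (0.37 log units; beyond the scatter), so steps in this small set have stayed modest. For the measured compounds named here, no measured step replaces ethyl with acetyl, which leaves the direction uncertain. Compound 3 already has the highest number, so a small move towards lower numbers in this assay seems more likely than a further rise, probably within the scatter. The expected change is a 1.5-fold lower number from compound 3 to compound 4 (0.19 log units; within the scatter). Compound 4 is estimated at 5000 nM, with an expected range from 2200 nM to 12000 nM.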

Compound 4, half-maximal inhibitory concentration: 1370 nM
Estimate against measurement, compound 4: 3.6-fold (0.56 log units) above; measured number outside the range, below it.
By their numbers in this assay, from the lowest: compounds 4, 2 and 1 (each within the scatter of the next, the first and the last beyond it); then compound 3.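

On an amine nitrogen in a ring, ethyl now stands apart from acetyl: in this assay, the change gives a 5.6-fold lower number from compound 3 to compound 4 (0.75 log units; beyond the scatter), the largest step in this set so far. Acetyl and methyl at the same nitrogen cannot be told apart, since the swap gives a 1.9-fold lower number from compound 2 to compound 4 (0.28 log units; within the scatter), so of the three groups tried here, only ethyl gives a number set apart from the others. The swap on the sulfur also now has two directions: with acetyl on the nitrogen it gives a 2.4-fold lower number from compound 1 to compound 4 (0.38 log units; beyond the scatter), opposite in direction to the step seen earlier with ethyl, so its outcome depends on the group at that nitrogen.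

Nothing in hand explains why ethyl differs from acetyl and methyl. Still open, as far as these compounds go, is whether a longer acyl chain such as propionyl, or a plain hydrogen on that nitrogen, would read like acetyl and methyl or like ethyl.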